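The source may report more compounds than this note shows. Statements on the series, on what has been measured and on what is new or still open speak of the compounds shown alone.

In a physicochemical assay for lipophilicity (a higher number here means a more lipophilic compound, a lower number a more polar compound), compound 1 `N#Cc1cccc(S(=O)(=O)N(Cc2ccc(Cl)cc2)C[C@@H]2CCC(=O)N2)c1` gives 3.1 and compound 2 `N#Cc1cccc(S(=O)(=O)N(Cc2cccc(Cl)c2)C[C@@H]2CCC(=O)N2)c1` gives 3, so these two values lie within the scatter of each other. Compound 3 `N#Cc1cccc(S(=O)(=O)N(Cc2ccccc2Cl)C[C@@H]2CCC(=O)N2)c1` has 2-chlorophenyl in place of 3-chlorophenyl on a saturated chain carbon bound to a sulfonamide nitrogen. Within the data shown here, only one measured step bears on this change, a number 0.10 log units lower from compound 1 to compound 2 (within the scatter), which also trades one chlorophenyl for another. No shift beyond the scatter is therefore expected in this assay, in either direction. The expected change is no change at the digits printed from compound 2 to compound 3 (within the scatter). The estimated value for compound 3 is 3, with an expected range from 2.7 to 3.3.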

Compound 3, distribution coefficient: 2.7
Compound 3: middle estimate off by 0.30 log units, on the high side; the measured number falls inside the stated range.
By their numbers in this assay, from the lowest: compounds 3, 2 and 1 (each within the scatter of the next, the first and the last beyond it).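

In this assay, among these compounds, 2-chlorophenyl in place of 4-chlorophenyl gives a number 0.40 log units lower from compound 1 to compound 3 (beyond the scatter) and is the first step here beyond the scatter, while 2-chlorophenyl in place of 3-chlorophenyl gives a number 0.30 log units lower from compound 2 to compound 3 (within the scatter) and stays within it. The place of the chlorine on this ring can therefore shift the number modestly, but this is shown only between the 2-chlorophenyl and 4-chlorophenyl compounds. Nothing available explains that shift.

Still open, as far as these compounds go, is how the number would respond to an unsubstituted phenyl, a 2-fluorophenyl or a pyridine ring at this place. From the compounds shown here alone, a longer chain carrying the ring is equally open.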